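Trimming the side chain of compound 2

A few compounds are considered here, and "the series" means these few. Any claim that something is new, unique, unknown or untested is made for them only; others in the source may bear on it.

Measured in a functional assay on HL-60 cells (Homo sapiens) for cytotoxicity, read by MTT assay, with a stated time of 96 h; a higher number here means a weaker inhibitor, a lower number a stronger inhibitor:
Compound 1 `CC[C@H](NC)C(=O)N[C@@H]1C(=O)N2[C@@H](CC[C@@H]1CN)CC[C@H]2C(=O)NC(c1ccccc1)c1ccccc1` gives 51800 nM
Compound 2 `CC[C@H](N)C(=O)N[C@@H]1C(=O)N2[C@@H](CC[C@@H]1CNC(=O)NCc1ccccc1)CC[C@H]2C(=O)NC(c1ccccc1)c1ccccc1` gives 51000 nM
Compound 3 `CC[C@H](NC)C(=O)N[C@@H]1C(=O)N2[C@@H](CC[C@@H]1CCN)CC[C@H]2C(=O)NC(c1ccccc1)c1ccccc1` gives 31000 nM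

Compound 2 lies within the usual scatter of both compound 1 and compound 3, so these three numbers cannot be ranked. Compound 4 `CC[C@H](N)C(=O)N[C@@H]1C(=O)N2[C@@H](CC[C@@H]1CCO)CC[C@H]2C(=O)NC(c1ccccc1)c1ccccc1` has not yet been measured. It differs from compound 2 at one place: hydroxymethyl in place of (benzylcarbamoyl)amino on a saturated chain carbon bound to a saturated ring carbon. Cut one bond further out, the same difference reads ((benzylcarbamoyl)amino)methyl to 2-hydroxyethyl.

Two observations bear on this change. The step of a 1.7-fold lower number from compound 1 to compound 3 (0.22 log units; within the scatter) puts aminomethyl in place of amino at this same place and stays within the scatter. Compound 2, carrying the large group, and compound 1, carrying amino there, also lie within the scatter of each other, though these two differ in a further place as well. Within the data shown here, no measured compound carries a hydroxyl group, so the evidence is thin. A step beyond the scatter in this assay is not expected in either direction. An estimated 1.3-fold lower number from compound 2 to compound 4 (0.11 log units; within the scatter) is what this expectation amounts to. The estimate for compound 4 is 40000 nM with a range from 15000 nM to 90000 nM expected.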

Compound 4, half-maximal inhibitory concentration: > 100000 nM
Compound 4 was reported as a limit; the forecaster's own chance of this, stated with the estimate: 15%; at least 2.5-fold (0.39 log units) between middle value and limit.
By their numbers in this assay, from the lowest: compounds 3, 2 and 1 (each within the scatter of the next). At a limit, above all of these: compound 4.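

In this assay compound 4 is reported only as a limit, > 100000 nM, so it has no exact number. The step reads an at least 1.9-fold higher number from compound 2 to compound 4 (0.29 log units; that floor lies within the scatter), and only its floor is known, so its true size could lie within the scatter or beyond it. Among these compounds, what is new is that a chain ending in a hydroxyl group, 2-hydroxyethyl, is the first group at this place to reach the limit of the assay, whereas compounds 1, 2 and 3, which all carry nitrogen there, each gave a number: the limit of > 100000 nM in this assay, at which 1 of the 4 values shown sits.

On these data alone, it remains open whether compound 4 stands apart through the hydroxyl group itself or through the loss of the (benzylcarbamoyl)amino group with its aromatic ring, and the limit does not show how far its true value lies from the others. Compounds that keep the rest of compound 4 but end this chain in a methyl ether or a carboxylic acid, or that carry a benzyl group without the urea, would help separate these readings.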